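From thiophen-2-yl to pyridin-3-yl in compound 4

The source may hold more compounds than are shown below. What is called first, only, known or untested is meant among the compounds shown, and "the series" means these compounds.

Measured in a functional assay on NCI-H661 cells (Homo sapiens) for antiproliferative activity, read by MTT assay, with a stated time of 72 h; on this read-out lower numbers stand for stronger inhibition and higher numbers for weaker inhibition:
- compound 1 `Cc1ccc(-c2noc(CCCCCCC(=O)NO)n2)cc1`: 15800 nM
- compound 2 `O=C(CCCCCCc1nc(-c2ccccc2Cl)no1)NO`: 10300 nM
- compound 3 `O=C(CCCCCCc1nc(-c2cccs2)no1)NO`: 9460 nM

Compound 3 stands within the scatter of both other compounds. Compound 4 `O=C(CCCCCCc1nc(-c2cccnc2)no1)NO` has pyridin-3-yl in place of thiophen-2-yl on an aromatic carbon. Three measured exchanges at this same place all stayed within the scatter: a 1.5-fold lower number from compound 1 to compound 2 (0.19 log units; within the scatter), a 1.7-fold lower number from compound 1 to compound 3 (0.22 log units; within the scatter) and a 1.1-fold lower number from compound 2 to compound 3 (0.04 log units; within the scatter). None of these compounds carries pyridin-3-yl, so the evidence is indirect. In this assay, no change beyond the scatter is expected, and the estimated step is a 1.2-fold higher number from compound 3 to compound 4 (0.07 log units; within the scatter). For compound 4 the estimated value is 11000 nM, with an expected range of 5000 nM to 25000 nM.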

Compound 4, half-maximal inhibitory concentration: 6020 nM
The estimate for compound 4 lay 1.8-fold (0.26 log units) above the measured number; measured number inside the range.
By their numbers in this assay, from the lowest: compounds 4, 3, 2 and 1 (each within the scatter of the next, the first and the last beyond it).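

In this assay, going by these compounds alone, pyridin-3-yl gives the first exchange at this aromatic carbon to pass the scatter, a modest one: a 2.6-fold lower number from compound 1 to compound 4 (0.42 log units; beyond the scatter) against 4-methylphenyl. Against the other two groups it stays within the scatter, with a 1.6-fold lower number from compound 3 to compound 4 (0.20 log units; within the scatter) and a 1.7-fold lower number from compound 2 to compound 4 (0.23 log units; within the scatter) leaving no order among compound 2, compound 3 and compound 4. Nothing available bears on why this exchange gives these numbers.

The compounds shown leave open what pyridin-4-yl, an aminophenyl group or a carboxylic acid would do at this place. On these data alone, how a longer chain would change the number also stays open.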